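The source may report more compounds than this note shows. Statements on the series, on what has been measured and on what is new or still open speak of the compounds shown alone.

Measured compounds:
Compound 1 `CCCCCCCN1CCC(C(=O)Nc2cc(Cl)c(N)cc2OC)CC1`: in a functional assay on the whole organism for antagonist activity, with Mus musculus as the target (on this read-out higher numbers stand for an effect only at larger amounts of compound and lower numbers for an effect already at smaller amounts), compound 1 gives > 10 mg/kg, a limit of the assay.
Compound 2 `CCCCCCN1CCC(C(=O)Nc2cc(Cl)c(N)cc2OC)CC1`: in this assay compound 2 gives > 10 mg/kg, likewise a limit of the assay.

Within the data shown here, compound 2 therefore stands only at a limit, and the limit of > 10 mg/kg in this assay, at which 2 of the 2 values shown sit, shows that every value so far sits at that same limit. Among the measured compounds shown here, the single measured step, a step that the two limits leave unreadable from compound 1 to compound 2, cannot be sized for this reason. Compound 3 `COc1cc(N)c(Cl)cc1NC(=O)C1CCN(C2CCCC2)CC1` differs from compound 2 by cyclopentyl in place of hexyl on an amine nitrogen in a ring. For the measured compounds named here, no measured step bears on this exchange, and the one step that exists gives no readable size, so nothing in the data points in either direction. The estimate for compound 3 is built only from the fact that compound 2 and its neighbour both sit at the limit: compound 3 is expected to show a step that the limit leaves unreadable from compound 2 to compound 3, with a value of 15 mg/kg and a range from 3 mg/kg to 60 mg/kg.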

Compound 3, dose for half-maximal effect: > 10 mg/kg
Compound 3 ended at the assay's limit (the forecaster's own chance of this, stated with the estimate: 70%); the middle value does not contradict the limit.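

Compound 3, like compound 1 and compound 2, gives only a limit in this assay and no step among the three can be read: the limit of > 10 mg/kg in this assay, at which 3 of the 3 values shown sit.

The compounds shown leave open what dose gives half-maximal effect with heptyl, hexyl or cyclopentyl on the amine nitrogen in the ring, and whether these groups differ at all.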